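This account rests on a few compounds, and the source may have more. Where it says the series, first, only, none or still open, it means among the compounds named here.

Working notes on the series. In a functional assay on HepG2 cells (Homo sapiens) for cytotoxicity, read by MTT assay, with a stated time of 72 h (on this read-out higher numbers stand for weaker inhibition and lower numbers for stronger inhibition), compound 1 (`CC[S+]([O-])CCCCN=C=S`) gives 5350 nM and compound 2 (`CCCC[S+]([O-])CCCCN=C=S`) gives 5930 nM as its value. These two values lie within the scatter of each other, so compound 2 stands level with compound 1 and the pair shows no ranking. The next structure is compound 3 (`CC(C)[S+]([O-])CCCCN=C=S`), which has isopropyl in place of butyl on a sulfur. Among the measured compounds shown here, the one measured step also changes the chain on that sulfur (a 1.1-fold higher number from compound 1 to compound 2 (0.04 log units; within the scatter)) and it stays within the scatter. No branched group on that sulfur has been measured yet, so this evidence is limited. On that basis, no change beyond the scatter is expected in this assay for this step. The estimated step is small (a 1.1-fold lower number from compound 2 to compound 3 (0.03 log units; within the scatter)) and within the scatter. The expected value for compound 3 is 5500 nM (estimated range 3000 nM to 10000 nM).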

Compound 3, half-maximal inhibitory concentration: 2050 nM
Compound 3: middle estimate off by 2.7-fold (0.43 log units), on the high side; measured number below the stated range.
By their numbers in this assay, from the lowest: compound 3; then compounds 1 and 2 (each within the scatter of the next).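

Among the compounds shown here, on the sulfur whose other neighbours are oxygen and a saturated chain carbon, isopropyl gives the first change beyond the scatter in this assay, modest in size, both against butyl (a 2.9-fold lower number from compound 2 to compound 3 (0.46 log units; beyond the scatter)) and against ethyl (a 2.6-fold lower number from compound 1 to compound 3 (0.42 log units; beyond the scatter)). Ethyl and butyl stand level (a 1.1-fold higher number from compound 1 to compound 2 (0.04 log units; within the scatter)), so among these three compounds the lower number goes with the one branched group and not with the straight chains, though that rests on compound 3 alone. No measurement at hand accounts for this difference.

The compounds shown leave open whether branching in general carries the change or whether it is particular to isopropyl, a question that tert-butyl or cyclopropyl on this sulfur would address. Also open, going by these compounds, is how a phenyl or a longer chain would stand there.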